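The source may report more compounds than this note shows. Statements on the series, on what has been measured and on what is new or still open speak of the compounds shown alone.

Working notes on the series, read in an ADME assay on J774.A1 cells (Mus musculus) for cytotoxicity, read by MTT assay, with a stated time of 72 h; a higher number here means that more compound is tolerated, a lower number that less compound is tolerated. Compound 1 `CC(C)c1ccc(C(Nc2ccc(C3(C)NC(=O)c4ccccc4N3)cc2)c2nnnn2C2CCCCC2)cc1` gives > 400000 nM, which is a limit of the assay and not a number. Compound 2 `CC(C)c1ccc(C(Nc2ccc(C3(C)NC(=O)c4ccccc4N3)cc2)c2nnnn2C(C)(C)C)cc1` gives > 400000 nM, also a limit. Compound 3 `Nc1nc(-c2ccccc2)cc(-c2ccc(C3NC(=O)c4ccccc4N3)cc2)n1` offers no result, its entry reading "not determined" (no result reported). The position of compound 1 is therefore known only as the limit of > 400000 nM in this assay, at which 2 of the 3 values shown sit.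

Compound 4 `CC1(c2ccc(NC(c3ccc(Cl)cc3)c3nnnn3C3CCCCC3)cc2)NC(=O)c2ccccc2N1` is compound 1 with one change: chloro in place of isopropyl on an aromatic carbon. This is chloro in place of isopropyl on an aromatic carbon, para to a large group, so 4-isopropylphenyl becomes 4-chlorophenyl.

For the measured compounds named here, the only measured step is a step that the two limits leave unreadable from compound 1 to compound 2. It concerns tert-butyl in place of cyclohexyl on an aromatic nitrogen, a different place from this change, and it gives no size to carry over. No step beyond the scatter is therefore expected in this assay, in either direction. The expected step is a number no higher from compound 1 to compound 4 (the limit leaves the size open). For compound 4 the estimated value is 400000 nM, with an expected range of 150000 nM to 800000 nM.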

Compound 4, half-maximal cytotoxic concentration: > 400000 nM
Compound 4: no number, only a limit; the forecaster's own chance of this, stated with the estimate: 75%; the middle value sits exactly at the limit.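

Compound 1 and compound 4 both stand at a limit of this assay and not at a number, and no step can be read between them. The compounds shown leave open at what concentration compound 1, compound 2 or compound 4 becomes cytotoxic, and whether chloro in place of isopropyl changes that concentration.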